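The compounds below may be only part of what the source reports. "The series", "measured", "known", "first", "only" and "open" are said of these compounds alone.

Of the compounds shown here, two of one series have been tested in a functional assay on cells for agonist activity at C-X-C chemokine receptor type 4 (Homo sapiens), read by fluorescence and calcium flux, with a stated time of 90 s (a lower number here means that less compound is needed, a higher number that more compound is needed for the effect), and both return only a limit of the assay rather than a number. Compound 1, `c1ccc2c(c1)CN[C@@H](CN(CCCCN(Cc1ccncc1)Cc1ccncc1)[C@H]1CCCc3cccnc31)C2`, in this assay gives > 30000 nM, which is a limit. Compound 2, `FC1(F)CCC(NCc2ccc(CN(C[C@H]3Cc4ccccc4CN3)[C@H]3CCCc4cccnc43)cc2)CC1`, in this assay gives > 30000 nM, again a limit and not a measured number. Within the data shown here, compound 2 therefore stands at the edge of what the assay can report, and the single other value shown sits at the same edge, as summarised by the limit of > 30000 nM in this assay, at which 2 of the 2 values shown sit. Among the measured compounds shown here, no step between two measured compounds can be drawn from these data.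

Compound 3, `c1ccc2c(c1)CN[C@@H](CN(Cc1ccc(CNC3CCOCC3)cc1)[C@H]1CCCc3cccnc31)C2`, has not yet been measured. It differs from compound 2 in one place: oxan-4-yl in place of 4,4-difluorocyclohexyl on an amine nitrogen. Since compound 2 reaches only a limit in this assay, no step in either direction beyond the usual scatter is expected; an estimated step of a number no higher from compound 2 to compound 3 (the limit leaves the size open) describes this expectation. Compound 3 is thus expected to give about 30000 nM in this assay, within a range from 10000 nM to 100000 nM, and most likely to be reported as a limit once more.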

Compound 3, half-maximal effective concentration: > 30000 nM
Compound 3 ended at the assay's limit (the forecaster's own chance of this, stated with the estimate: 85%); the middle value lies on the limit itself.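

In this assay no step can be read between compound 2 and compound 3, because each returns only a limit and not a number: the limit of > 30000 nM in this assay, at which 3 of the 3 values shown sit.

The compounds shown leave open whether any of the three gives a measurable value in this assay, and so how oxan-4-yl and 4,4-difluorocyclohexyl on an amine nitrogen compare.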